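Chain-extended isothiocyanate amide in the pyrrolopyrimidine series

The source may hold more compounds than are shown below. What is called first, only, known or untested is meant among the compounds shown, and "the series" means these compounds.

Compound 2 `CN(C)C(=O)c1cc2cnc(Nc3ccc(C(=O)NCCCCN=C=S)cc3)nc2n1C1CCCC1` carries the amide-linked isothiocyanate chain on the shared core. Among the compounds with values here, in a functional assay on A549 cells (Homo sapiens) for inhibition, read by CCK-8 assay, with a stated time of 72 h, tested at 10 uM (on this read-out higher numbers stand for a stronger effect at the one concentration tested and lower numbers for a weaker effect), compound 2 gives 102%, the highest of the two numbers so far, with compound 1 `CN(C)C(=O)c1cc2cnc(Nc3ccc(S(=O)(=O)NCCCCN=C=S)cc3)nc2n1C1CCCC1` next to it: compound 1 gives 101% in this assay, and the step of a number 1 percentage points higher from compound 1 to compound 2 (within the scatter) lies within the scatter, so the two are indistinguishable on this read-out.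

Compound 3 `CN(C)C(=O)c1cc2cnc(Nc3ccc(C(=O)NCCCCCCCN=C=S)cc3)nc2n1C1CCCC1` differs from compound 2 only in the length of the chain between the amide and the isothiocyanate: a group of 6 heavy atoms (4 carbon, 1 nitrogen, 1 sulfur; no ring) in place of a group of 3 heavy atoms (1 carbon, 1 nitrogen, 1 sulfur; no ring), on a saturated chain carbon, four bonds along the chain from an amide-type nitrogen.

Within the data shown here, no measured step changes this chain length; the one step available, from compound 1 to compound 2, exchanges the linking group on the aromatic carbon and is flat. Both measured compounds sit at the top of the read-out at the single concentration, which leaves no room for a rise and gives no hint of a fall. The expectation for compound 3 is therefore a step of a number 2 percentage points lower from compound 2 to compound 3 (within the scatter) in this assay, none beyond the scatter. Compound 3 is estimated at 100%, between 88% and 106%.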

Compound 3, a percentage reported as inhibition, at one concentration (the size of the read-out at that concentration, not a potency): 101%
Estimate against measurement, compound 3: 1 percentage points below; the measured number falls inside the stated range.
By their numbers in this assay, from the lowest: compounds 1, 3 and 2 (each within the scatter of the next).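

Within the data shown here, at the saturated chain carbon, four bonds along the chain from an amide-type nitrogen, the group of 6 heavy atoms in place of the group of 3 heavy atoms gives a number 1 percentage points lower from compound 2 to compound 3 (within the scatter) in this assay and so provides the first reading on chain length, where the earlier step concerned only the linking group on the aromatic carbon. The terminal isothiocyanate is present in both compounds, and on this read-out at the single concentration the two chain lengths cannot be told apart. No available evidence bears on this result.

All three compounds sit at the top of the read-out at one concentration, so any difference in potency among them remains unresolved, and a concentration series would be needed to separate them. Also open, from the compounds shown here alone, is whether a shorter chain, a longer chain, or an amine or carboxylic acid in place of the isothiocyanate would give a number beyond the scatter at this position.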